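Moving the amino group of compound 3

The source may hold more compounds than are shown below. What is called first, only, known or untested is meant among the compounds shown, and "the series" means these compounds.

Measured in a functional assay on SK-OV-3 cells (Homo sapiens) for inhibition, read by CCK-8 assay, with a stated time of 70 h; on this read-out lower numbers stand for stronger inhibition and higher numbers for weaker inhibition:
Compound 1 `c1ccc(COc2ccc(OCCOCCNC3CCCC3)cc2)cc1`: 24800 nM
Compound 2 `O=C(O)c1cccc(COc2ccc(OCCOCCNC3CCCC3)cc2)c1`: > 100000 nM, a limit of the assay
Compound 3 `Nc1ccccc1COc1ccc(OCCOCCNC2CCCC2)cc1`: 14000 nM

Compound 3 gives 14000 nM. Placing amino on the ring in place of hydrogen produced a 1.8-fold lower number from compound 1 to compound 3 (0.25 log units; within the scatter), so compound 3 stands level with compound 1 rather than ahead of it. Compound 2 reads > 100000 nM, which is a limit and not a number. Carboxy in place of hydrogen produced an at least 4.0-fold higher number from compound 1 to compound 2 (0.60 log units; beyond the scatter), and exchanging the whole substituted ring produced an at least 7.1-fold lower number from compound 2 to compound 3 (0.85 log units; beyond the scatter). These two steps show that a different group on this ring can shift the result beyond the scatter.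

Compound 4 `Nc1ccc(COc2ccc(OCCOCCNC3CCCC3)cc2)cc1` has the same atoms as compound 3, joined differently: 4-aminophenyl in place of 2-aminophenyl on a saturated chain carbon bound to an oxygen on an aromatic ring. For the measured compounds named here, the group remains amino, and no measured step shows what moving it does. The closest guide is the amino step, a 1.8-fold lower number from compound 1 to compound 3 (0.25 log units; within the scatter), which stayed within the scatter, whereas the larger steps involved carboxy. The expected change is therefore small, and the estimated step is a 1.1-fold higher number from compound 3 to compound 4 (0.03 log units; within the scatter), with no clear shift expected in either direction. For compound 4 the expected value in this assay is 15000 nM, with an estimated range from 6000 nM to 40000 nM.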

Compound 4, half-maximal inhibitory concentration: 31700 nM
Compound 4: the middle estimate sits 2.1-fold (0.32 log units) below what was measured; the range from low to high includes it.
By their numbers in this assay, from the lowest: compounds 3, 1 and 4 (each within the scatter of the next, the first and the last beyond it). At a limit, above all of these: compound 2.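

In this assay, for the compounds shown here, the atoms stay the same and only the place of the amino group changes, from 2-aminophenyl to 4-aminophenyl, giving a 2.3-fold higher number from compound 3 to compound 4 (0.35 log units; beyond the scatter); this shows that where amino sits on this ring can matter by itself, which the earlier steps could not show because each of them changed the group. Set against the unsubstituted ring of compound 1, neither placement separates from it, with a 1.8-fold lower number from compound 1 to compound 3 (0.25 log units; within the scatter) and a 1.3-fold higher number from compound 1 to compound 4 (0.11 log units; within the scatter), so the shift beyond the scatter appears only between the two amino compounds. The last step, an at least 3.1-fold lower number from compound 2 to compound 4 (0.49 log units; beyond the scatter), starts from a limit and not a number, the reading of compound 2: the limit of > 100000 nM in this assay, at which 1 of the 4 values shown sits.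

The compounds shown do not say why the place of the amino group changes the number, or whether the same holds for other groups on this ring, such as a hydroxyl, a methoxy or an amide. They also leave open whether this difference between the two amino compounds would survive a longer chain in the shared core.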